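This account rests on a few compounds, and the source may have more. Where it says the series, first, only, none or still open, it means among the compounds named here.

In an assay for inhibition of steroid 17-alpha-hydroxylase/17,20 lyase (Homo sapiens), tested at 0.2 uM (a lower number here means a weaker effect, a higher number a stronger effect of the compound at the concentration tested), the three measured compounds gave these numbers:

compound 1, `Fc1ccc(-c2ccc3c(-c4cccnc4)cccc3c2)cc1`: 2%
compound 2, `Fc1ccc(-c2ccc3c(-c4ccncc4)cccc3c2)cc1`: 1%
compound 3, `COc1ccc2cc(-c3cccc(-c4cccnc4)c3)ccc2c1`: 3%

All three numbers are small, and each lies within the usual scatter of the others, so none of the three can be told apart from the rest in this assay. Compound 1 and compound 2 share a core and differ in one place: pyridin-4-yl in place of pyridin-3-yl on an aromatic carbon. The step this made was a number 1 percentage points lower from compound 1 to compound 2 (within the scatter), which is within the scatter and so shows no real effect of the change.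

Compound 3 has a different core from compound 1; how the two cores differ is not broken down here. Compound 4, `COc1ccc2cc(-c3cccc(-c4ccncc4)c3)ccc2c1`, has not yet been measured. It is related to compound 3 by the same kind of change: pyridin-4-yl in place of pyridin-3-yl on an aromatic carbon. The surroundings of the place are not the same as in the earlier pair: in compound 1 the change sits on a ring that is part of a fused or bridged system of two rings, ortho to a fused ring and meta to a fused ring, whereas in compound 3 it sits on a six-membered aromatic ring of carbon only, meta to a large group.

Because the earlier step of a number 1 percentage points lower from compound 1 to compound 2 (within the scatter) was within the scatter and compound 3 itself gave only 3%, the step from compound 3 to compound 4 is expected to be small, a number 1 percentage points lower from compound 3 to compound 4 (within the scatter). Compound 4 is therefore estimated at 2% in this assay, most likely between 0% and 9%.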

Compound 4, a percentage reported as inhibition, at one concentration (the size of the read-out at that concentration, not a potency): 4%
Compound 4: middle estimate off by 2 percentage points, on the low side; the measured number falls inside the stated range.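

In this assay, putting pyridin-4-yl in place of pyridin-3-yl gave a number 1 percentage points higher from compound 3 to compound 4 (within the scatter), so on this second core the change again leaves no mark that can be read. Set beside the step on the first core, the new step cannot be told apart from it: the same change on two cores in this assay, a number 1 percentage points lower (within the scatter) from compound 1 to compound 2 and a number 1 percentage points higher (within the scatter) from compound 3 to compound 4, 2 percentage points apart, within the scatter of two such steps. This shows that, in this series and at this single concentration, the swap behaves alike on the two cores, but it does not show that the choice between pyridin-3-yl and pyridin-4-yl is unimportant for the enzyme, as all the numbers are small and a single low reading per compound has little room to reveal a difference, so a real effect of the change could remain hidden here.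

The compounds shown leave open whether a different ring at this place, such as an imidazole or a pyrimidine, would give a number clearly beyond the scatter, and whether a hydroxyl group or an amine in place of the methoxy group of compound 3 would do so. They also leave open how the two pyridine isomers would compare at a higher concentration, where one might show a stronger or weaker effect than the other.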